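The compounds below may be only part of what the source reports. "The series", "measured", "known", "first", "only" and "open" are said of these compounds alone.

Of the compounds shown here, three have so far been measured in an assay on BTI-TN-5B1-4 cells for inhibition of Amine oxidase [flavin-containing] B (Homo sapiens), read by fluorescence and Amplex Red, using microsomes, with a stated time of 15 min; a higher number here means a weaker inhibitor, a lower number a stronger inhibitor. Compound 1 `C#CCN1CCC(OC(=O)Nc2ccccc2)CC1` gives in this assay > 100000 nM, which is a limit of the assay rather than a number. Compound 2 `C#CCN1CCCC(OC(=O)Nc2ccccc2)C1` gives in this assay > 100000 nM, likewise a limit. The difference between the cores of compound 1 and compound 2 is not broken down here. Compound 3 `C#CCN1CCC(OC(=O)Nc2ccc(C(C)C)cc2)CC1` gives in this assay 178 nM. Compound 3 differs from compound 1 by isopropyl in place of hydrogen on an aromatic carbon, and this change brought an at least 560-fold lower number from compound 1 to compound 3 (2.74 log units; beyond the scatter); the full size of that step is open because of the limit of > 100000 nM in this assay, at which 2 of the 3 values shown sit. Compound 4 `C#CCN1CCCC(OC(=O)Nc2ccc(C(C)C)cc2)C1` has not been measured. It differs from compound 2 by isopropyl in place of hydrogen on an aromatic carbon, the same change. The step is expected to be an at least 250-fold lower number from compound 2 to compound 4 (2.39 log units; beyond the scatter) because the same change gave an at least 560-fold lower number from compound 1 to compound 3 (2.74 log units; beyond the scatter). Compound 4 is thus estimated to give 400 nM in this assay, likely between 80 nM and 5000 nM.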

Compound 4, half-maximal inhibitory concentration: 71800 nM
The estimate for compound 4 lay 180-fold (2.25 log units) below the measured number, outside the stated range (above it).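

In this assay, putting the isopropyl group on the aromatic ring of the second core gave an at least 1.3-fold lower number from compound 2 to compound 4 (0.14 log units; that floor lies within the scatter). This does not show that the change carries over from one core to the other with the same effect, nor does it show that the effect differs between them: the same change on two cores in this assay, an at least 560-fold lower number (2.74 log units; beyond the scatter) from compound 1 to compound 3 and an at least 1.3-fold lower number (0.14 log units; that floor lies within the scatter) from compound 2 to compound 4; the limit leaves it open whether they differ. As far as these compounds go, compound 2 has a limit and not a number, so the true size of its step stays unknown: the limit of > 100000 nM in this assay, at which 2 of the 4 values shown sit.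

The compounds shown leave open how other groups at the same place on the aromatic ring, such as a methoxy group or a chlorine atom, would behave on each core. They also leave open whether a group smaller than isopropyl, such as methyl, would give a step that can be read in full.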